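A few compounds are considered here, and "the series" means these few. Any claim that something is new, unique, unknown or untested is made for them only; others in the source may bear on it.

Measured in an ADME assay on microsomes from liver (Mus musculus) for metabolic stability, read by LC-MS, using NADPH, with a stated time of 10 min, tested at 0.5 uM; on this read-out lower numbers stand for a less stable compound and higher numbers for a more stable compound:
- compound 1 `COC(=O)Nc1cc(-c2ccc(OC[C@@](C)(N)CC(C)C)cn2)ccn1`: 93%
- compound 2 `CC(=O)Nc1cc(-c2ccc(OC[C@@H](N)CC(C)C)c(C)c2)ccn1`: 64%
- compound 3 `CC(=O)Nc1cc(-c2cc(F)c(OC[C@@H](N)CC(C)C)cc2F)ccn1`: 70%

Compound 2, at 64%, cannot be told apart from compound 3, at 70%, as the two lie within the usual scatter. Compound 1, at 93%, stands above compound 2 by more than the scatter, though these two differ in more than one place.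

Compound 4 `CC(=O)Nc1cc(-c2ccc(OC[C@@H](N)CC(C)C)c(OC(F)(F)F)c2)ccn1` is built from compound 2 by a single change: trifluoromethoxy in place of methyl on an aromatic carbon, ortho to a (2-amino-4-methylpentyl)oxy group (trifluoromethoxy in place of methyl on an aromatic carbon). Within the data shown here, no two measured compounds differ in only one place, so the data offer no direct guide to this swap. The expectation in this assay is therefore cautious: a small upward move at most, with nothing beyond the scatter. The expected change is a number 4 percentage points higher from compound 2 to compound 4 (within the scatter). The estimated value for compound 4 is 68%, with an expected range from 48% to 86%.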

Compound 4, percent of the compound remaining: 35%
For compound 4 the middle estimate is 33 percentage points above the measured one, outside the stated range (below it).
By their numbers in this assay, from the lowest: compound 4; then compounds 2 and 3 (each within the scatter of the next); then compound 1.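

In this assay, among these compounds, the step of a number 29 percentage points lower from compound 2 to compound 4 (beyond the scatter) is the first comparison here in which only one place changes, and it lies beyond the scatter. It shows that the group on this aromatic carbon, ortho to a (2-amino-4-methylpentyl)oxy group, matters for how much compound remains, and that trifluoromethoxy in place of methyl goes with less remaining in this pair. Nothing measured here gives a reason for this fall.

As far as these compounds go, what stays open is whether the fall is particular to trifluoromethoxy or would also appear with another group on this carbon, such as trifluoromethyl, a chlorine atom or a nitrile. Also open, from the compounds shown here alone, is whether the same swap would lower the number on the core of compound 1 or compound 3.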